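Capping the Amine of Compound 3 with Methylsulfonyl

The source may hold more compounds than are shown below. What is called first, only, known or untested is meant among the compounds shown, and "the series" means these compounds.

Compound 3 `CC(C)(C)C1=C(C(=O)O)N2C(=O)[C@H](CN)[C@H]2O1` stands lowest of the three measured compounds in an ADME assay, in phosphate buffer, at 28 degrees C, at pH 7.0; on this read-out lower numbers stand for a shorter-lived compound and higher numbers for a longer-lived compound: compound 3 gives 1.2 h, whereas compound 1 `CC(C)(C)C1=C(C(=O)O)N2C(=O)[C@H](CO)[C@H]2O1` gives 5 h and compound 2 `COC(=O)[C@@H](O)[C@H]1C(=O)N2C(C(=O)O)=C(C(C)(C)C)O[C@H]12` gives 6.2 h. Both gaps, a 4.2-fold lower number from compound 1 to compound 3 (0.62 log units; beyond the scatter) and a 5.2-fold lower number from compound 2 to compound 3 (0.71 log units; beyond the scatter), lie beyond the scatter. Compound 4 `CC(C)(C)C1=C(C(=O)O)N2C(=O)[C@H](CNS(C)(=O)=O)[C@H]2O1` differs from compound 3 by methylsulfonyl in place of hydrogen on an amine nitrogen. Going by the values given here, no measured step covers this exact change; the closest guide is a 4.2-fold lower number from compound 1 to compound 3 (0.62 log units; beyond the scatter), the step in which the amino group arrives. Since the change to compound 4 covers that same amino group, a move back toward the level of compound 1 is expected, namely a 3.3-fold higher number from compound 3 to compound 4 (0.52 log units; beyond the scatter). Compound 4 is accordingly estimated at 4 h, with a range from 1.5 h to 10 h.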

Compound 4, half-life: 2.2 h
Compound 4: the middle estimate sits 1.8-fold (0.26 log units) above what was measured; measured number inside the range.
By their numbers in this assay, from the lowest: compounds 3 and 4 (each within the scatter of the next); then compounds 1 and 2 (each within the scatter of the next).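

On this position, methylsulfonyl on the amine nitrogen gives a change in half-life that stays within the scatter (a 1.8-fold higher number from compound 3 to compound 4 (0.26 log units; within the scatter)). The methanesulfonamido group also stays short of the hydroxy group (a 2.3-fold lower number from compound 1 to compound 4 (0.36 log units; beyond the scatter)) and of hydroxy(methoxycarbonyl)methyl (a 2.8-fold lower number from compound 2 to compound 4 (0.45 log units; beyond the scatter)), so capping this amine with methylsulfonyl does not recover their level. As far as these compounds go, whether an acetyl group on the same nitrogen, or a longer chain in place of the methyl on the sulfonyl, would give a different half-life remains open. Nothing available here explains the result.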